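Two Limits and a Third Change Still Untested

The source may hold more compounds than are shown below. What is called first, only, known or untested is meant among the compounds shown, and "the series" means these compounds.

Compound 1 `O=C(NC[C@H]1CN(c2ccc(N3CCC(C(=O)O)CC3)cc2)C(=O)O1)c1ccc(Cl)s1`: in an assay on isolated protein for inhibition of Trypsin (Homo sapiens), read by spectrophotometry, with a stated time of 15 min (on this read-out lower numbers stand for stronger inhibition and higher numbers for weaker inhibition), compound 1 gives > 100000 nM, a limit of the assay.
Compound 2 `O=C(NC[C@H]1CN(c2ccc(N3CCC(C(=O)O)CC3=O)cc2)C(=O)O1)c1ccc(Cl)s1`: in this assay compound 2 gives > 100000 nM, also a limit.

Both values sit at the limit of > 100000 nM in this assay, at which 2 of the 2 values shown sit, so a step that the two limits leave unreadable from compound 1 to compound 2 cannot be read. Compound 2 thus stands at the limit, with no number of its own. Compound 3 `CCOC(=O)C1CCCCN1c1ccc(N2C[C@H](CNC(=O)c3ccc(Cl)s3)OC2=O)cc1` differs from compound 2 in one place: 2-(ethoxycarbonyl)piperidin-1-yl in place of 4-carboxy-2-oxopiperidin-1-yl on an aromatic carbon. No measured step bears on this change, and nothing shown points to a reading below the limit. Compound 3 is therefore expected at 100000 nM (range 30000 nM to 300000 nM), an expected step of a number no higher from compound 2 to compound 3 (the limit leaves the size open) in this assay.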

Compound 3, inhibition constant: > 100000 nM
Compound 3 ended at the assay's limit; the forecaster's own chance of this, stated with the estimate: 85%; the middle value sits exactly at the limit.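

No step can be read among compound 1, compound 2 and compound 3, since all three rest on the same limit: the limit of > 100000 nM in this assay, at which 3 of the 3 values shown sit.

The compounds shown leave open what, if anything, would bring a reading under that limit in this assay.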